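Amide replaces aryl on the piperazine nitrogen

This account rests on a few compounds, and the source may have more. Where it says the series, first, only, none or still open, it means among the compounds named here.

Measured compounds:
compound 1, `CC(C)(Oc1ccc(Cl)cc1)C(=O)N1CCN(c2nc(N)nc3sc(-c4ccc(F)cc4)nc23)CC1`: > 10000 nM
compound 2, `Cc1cccc(N2CCN(c3nc(N)nc4sc(-c5ccc(F)cc5)nc34)CC2)c1`: > 10000 nM

Of the compounds shown here, two have been tested in a functional assay on cells (Lymphocyte, Homo sapiens); on this read-out lower numbers stand for stronger inhibition and higher numbers for weaker inhibition. Compound 1 carries an amide on the ring nitrogen of the shared core and gives > 10000 nM, which is a limit of the assay rather than a number. Compound 2 carries an aryl group on that same nitrogen and gives > 10000 nM, again only a limit. For the measured compounds named here, compound 2 therefore stands at the limit of the assay, as does the other value shown (the limit of > 10000 nM in this assay, at which 2 of the 2 values shown sit); neither tested compound gives a measurable inhibition, and no step between them can be sized.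

Compound 3, `Nc1nc(N2CCN(C(=O)COc3ccc(F)cc3)CC2)c2nc(-c3ccc(F)cc3)sc2n1`, differs from compound 2 in one place: ((4-fluorophenoxy)methyl)carbonyl in place of 3-methylphenyl on an amine nitrogen in a ring. Going by the values given here, no measured step covers this kind of change. Both tested compounds sit at the limit, and compound 1 already shows that an amide at this position does not bring the read-out into range. For compound 3 the step is expected to be a step that the limit leaves unreadable from compound 2 to compound 3, with the most likely outcome again a limit. Compound 3 is estimated at 15000 nM, within a range from 3000 nM to 60000 nM.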

Compound 3, half-maximal inhibitory concentration: 70 nM
Estimate against measurement, compound 3: 210-fold (2.33 log units) above; the measured number lies below the stated range.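

In this assay, for the compounds shown here, ((4-fluorophenoxy)methyl)carbonyl in place of 3-methylphenyl on the amine nitrogen in a ring gives an at least 140-fold lower number from compound 2 to compound 3 (2.15 log units; beyond the scatter), the first sign that a group at this position can bring the read-out into a measurable range. An amide at this nitrogen is not enough on its own: compound 1 also has a carbonyl there, and the change on the carbonyl carbon, a group of 9 heavy atoms with fluorine in place of a group of 11 heavy atoms with chlorine, gives an at least 140-fold lower number from compound 1 to compound 3 (2.15 log units; beyond the scatter), so the group on that carbon matters as well. Both steps give only a lower bound on the size of the change, because each starts from a limit of the assay: the limit of > 10000 nM in this assay, at which 2 of the 3 values shown sit.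

The compounds shown leave open whether the loss in compound 1 comes from its two methyl groups on the carbon bearing the ring oxygen or from its chlorine in place of fluorine, since the two differences arrive together. Also open, going by these compounds, is how this assay would respond to a longer chain on the carbonyl carbon or to an amine in place of the ether oxygen.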